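Swapping the acetal tail for an aminoethyl amide

The source may report more compounds than this note shows. Statements on the series, on what has been measured and on what is new or still open speak of the compounds shown alone.

Measured compounds:
- compound 1, `CCn1c(C(=O)NCCN)ccc1C(CC)(CC)c1ccc(OCC(=O)C(C)(C)C)c(C)c1`: 1010 nM
- compound 2, `C#CCNC(=O)c1ccc(C(CC)(CC)c2ccc(OCC(O)C(C)(C)C)c(C)c2)n1CC`: > 10000 nM
- compound 3, `CCn1c(C(=O)NCC(OC)OC)ccc1C(CC)(CC)c1ccc(OCC(O)C(C)(C)C)c(C)c1`: 5240 nM

In an assay on isolated protein for binding affinity to vitamin D3 receptor (Homo sapiens), with a stated time of 4 h (a lower number here means a stronger inhibitor, a higher number a weaker inhibitor), compound 3 gives 5240 nM, the higher of the two numbers actually reported; compound 1 gives 1010 nM, a gap beyond the usual scatter. For compound 2 this assay gives only a limit, > 10000 nM, not a number, as noted in the limit of > 10000 nM in this assay, at which 1 of the 3 values shown sits.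

Compound 4, `CCn1c(C(=O)NCCN)ccc1C(CC)(CC)c1ccc(OCC(O)C(C)(C)C)c(C)c1`, is compound 3 with one change: aminomethyl in place of dimethoxymethyl on a saturated chain carbon bound to an amide-type nitrogen. Going by the values given here, only one measured step touches this part of the molecule, an at least 1.9-fold lower number from compound 2 to compound 3 (0.28 log units; that floor lies within the scatter), and its size is not better known than the floor allows. The aminoethyl amide of compound 4 also appears, on a different side chain, in compound 1, and compound 1 gives 1010 nM, which suggests this amide is compatible with a measurable number. An improvement is therefore expected, of modest size, a 2.1-fold lower number from compound 3 to compound 4 (0.32 log units; beyond the scatter). Compound 4 is estimated at 2500 nM, within 800 nM to 8000 nM.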

Compound 4, half-maximal inhibitory concentration: 194 nM
Compound 4: middle estimate off by 13-fold (1.11 log units), on the high side, outside the stated range (below it).
By their numbers in this assay, from the lowest: compound 4; then compound 1; then compound 3. At a limit, above all of these: compound 2.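

In this assay the tail on the amide nitrogen proves decisive: 2-aminoethyl in place of 2,2-dimethoxyethyl gives a 27-fold lower number from compound 3 to compound 4 (1.43 log units; beyond the scatter) and aminomethyl in place of ethynyl gives an at least 51-fold lower number from compound 2 to compound 4 (1.71 log units; beyond the scatter) at the same place. That second step is only a floor, since compound 2 carries a limit and not a number: the limit of > 10000 nM in this assay, at which 1 of the 4 values shown sits.

A second place matters as well: on a saturated chain carbon bound to an oxygen on an aromatic ring, 1-hydroxy-2,2-dimethylpropyl in place of (tert-butyl)carbonyl gives a 5.2-fold lower number from compound 1 to compound 4 (0.72 log units; beyond the scatter) with the 2-aminoethyl tail held constant.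

Which feature of the 2-aminoethyl tail carries the gain stays open. A 2-hydroxyethyl or a 3-aminopropyl group on the amide nitrogen would separate the role of the terminal amine from that of the chain length.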